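Swapping the aniline group on the hexyl compound

The compounds below may be only part of what the source reports. "The series", "measured", "known", "first", "only" and "open" are said of these compounds alone.

Measured in a functional assay on BT-474 cells (Homo sapiens) for inhibition, read by fluorescence, with a stated time of 72 h (a higher number here means a weaker inhibitor of growth, a lower number a stronger inhibitor of growth), so far
- compound 1 `CC(C)=CCn1cnc2c(Nc3cccc(Cl)c3)nc(N[C@H]3CC[C@H](N)CC3)nc21` gives 7000 nM
- compound 2 `CCCCCCn1cnc2c(Nc3cc(OC)cc(OC)c3)nc(N[C@H]3CC[C@H](N)CC3)nc21` gives 3700 nM

These two values lie within the usual scatter of each other, so compound 2 stands level with compound 1 and no order can be read between them. Among the compounds with values here, with only two measurements, the series has no ranking yet and no pattern to extend.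

Compound 3 `CCCCCCn1cnc2c(Nc3cccc(Cl)c3)nc(N[C@H]3CC[C@H](N)CC3)nc21` differs from compound 2 in one place (3-chlorophenyl in place of 3,5-dimethoxyphenyl on a nitrogen on an aromatic ring), with 3-chlorophenyl in place of 3,5-dimethoxyphenyl on a nitrogen on an aromatic ring. No measured pair isolates this change, so its size in this assay is not shown directly. With compound 1 at 7000 nM and compound 2 at 3700 nM, nothing measured points to a large move. The expected step of a 1.1-fold higher number from compound 2 to compound 3 (0.03 log units; within the scatter) stays within the scatter, with neither direction favoured. Compound 3 is estimated at 4000 nM, with an expected range of 1800 nM to 8500 nM in this assay.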

Compound 3, concentration for 50% growth inhibition: 5100 nM
Beside the measured number, compound 3's estimate is 1.3-fold (0.11 log units) below it, within the range that was stated.
By their numbers in this assay, from the lowest: compounds 2, 3 and 1 (each within the scatter of the next).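

In this assay, the first pair isolating the aryl group on this amino nitrogen shows that 3-chlorophenyl in place of 3,5-dimethoxyphenyl gives a 1.4-fold higher number from compound 2 to compound 3 (0.14 log units; within the scatter), so the loss of both methoxy groups and the arrival of the chlorine leave the number level at this position. Within the data shown here, compound 3 also isolates the chain on the aromatic nitrogen for the first time, and pentyl in place of 2-methylprop-1-en-1-yl on a saturated chain carbon bound to an aromatic nitrogen gives a 1.4-fold lower number from compound 1 to compound 3 (0.14 log units; within the scatter), so neither single change separates the compounds and all three stand level in this assay. No measurement is available that bears on why these exchanges leave the number level.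

From the compounds shown here alone, whether any group at the aryl position can move the number beyond the scatter remains open, for example a carboxylic acid or a nitrile on the phenyl ring in place of the chlorine. The same question stands for the chain on the aromatic nitrogen, where a longer chain such as octyl or a terminal amine could be compared with the hexyl chain of compound 3.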